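Solubility step from compound 1 to compound 4

The compounds below may be only part of what the source reports. "The series", "measured", "known", "first", "only" and "open" are said of these compounds alone.

Compound 1 `COc1ccc2[nH]c(C(=O)N3CC(=O)N(Cc4ccccc4)[C@@H](CN4CCC(OC)CC4)C3)cc2c1` is measured in a physicochemical assay for solubility, read by spectrophotometry, in phosphate buffer, with a stated time of 2 h, at pH 7.4 (a lower number here means a less soluble compound, a higher number a more soluble compound), where compound 1 gives only a limit, > 25000 nM, and no number. Compound 2 `COc1ccc2[nH]c(C(=O)N3CC(=O)N(Cc4cccc(OC)n4)[C@@H](Cc4ccccc4)C3)cc2c1` gives 47500 nM in this assay. Compound 3 `COc1ccc2[nH]c(C(=O)N3CC(=O)N(c4ccccc4)[C@@H](Cc4ccccc4)C3)cc2c1` gives 36100 nM in this assay. For the measured compounds named here, the one measured step, a 1.3-fold lower number from compound 2 to compound 3 (0.12 log units; within the scatter), changes the group on an amide-type nitrogen in a ring and stays within the scatter. Compound 4 `COc1ccc2[nH]c(C(=O)N3CC(=O)N(Cc4ccccc4)[C@@H](CN4C(=O)c5ccccc5C4=O)C3)cc2c1` is not yet measured in this assay. It differs from compound 1 by a group of 11 heavy atoms (8 carbon, 1 nitrogen, 2 oxygen; one five-membered non-aromatic ring with 1 hetero atom, one six-membered aromatic ring of carbon only) in place of a group of 8 heavy atoms (6 carbon, 1 nitrogen, 1 oxygen; one six-membered non-aromatic ring with 1 hetero atom), on a saturated chain carbon bound to a saturated ring carbon. Going by the values given here, no measured step touches this place: the step of a 1.3-fold lower number from compound 2 to compound 3 (0.12 log units; within the scatter) sits at a different place in the molecule, and compound 1 itself stands only at the limit of > 25000 nM in this assay, at which 1 of the 3 values shown sits. The size and direction of the change in this assay therefore cannot be read from the measured pairs, and the scatter of the measured step offers no guide. Compound 4 is expected to give about 10000 nM, with a range from 2000 nM to 40000 nM. This expectation amounts to an estimated at least 2.5-fold lower number from compound 1 to compound 4 (0.39 log units; beyond the scatter), held with little confidence.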

Compound 4, solubility: > 100000 nM
Compound 4: no number, only a limit (the forecaster's own chance of this, stated with the estimate: 30%); at least 10-fold (1.00 log units) between middle value and limit.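

In this assay compound 1 and compound 4 each give only a limit, not a number, and the step between them cannot be read. The compounds shown leave open the size and direction of the solubility change when the group on this saturated chain carbon is exchanged.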